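The source may report more compounds than this note shows. Statements on the series, on what has been measured and on what is new or still open speak of the compounds shown alone.

Measured compounds:
compound 1 `CCOC(=O)[C@@H]1CC(=O)c2sccc2[C@H]1c1ccc(OC)cc1` — 13%
compound 2 `CCOC(=O)[C@@H]1CC(=O)c2sccc2[C@H]1c1ccc(OCC)cc1` — 15.4%

Of the compounds shown here, two sharing one core have been measured in a physicochemical assay, with a stated time of 60 min, tested at 20 ug/mL; a higher number here means a stronger effect of the compound at the concentration tested, a lower number a weaker effect. Compound 1 `CCOC(=O)[C@@H]1CC(=O)c2sccc2[C@H]1c1ccc(OC)cc1` gives 13%. Compound 2 `CCOC(=O)[C@@H]1CC(=O)c2sccc2[C@H]1c1ccc(OCC)cc1`, which differs only by a methyl in place of hydrogen on a saturated chain carbon bound to an oxygen on an aromatic ring, gives 15.4%; the step of a number 2.4 percentage points higher from compound 1 to compound 2 (within the scatter) lies within the scatter, so the two numbers cannot be told apart.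

The next compound, compound 3 `CCOC(=O)[C@@H]1CC(=O)c2sccc2[C@H]1c1ccc(OC)c(OC)c1`, is not yet measured. It differs from compound 1 as follows:

methoxy in place of hydrogen on an aromatic carbon

Among the compounds with values here, the only measured step, a number 2.4 percentage points higher from compound 1 to compound 2 (within the scatter), altered a group on that same ring and left this assay essentially unchanged. It does not test a new methoxy on the ring itself, so it only weakly bears on compound 3. With nothing pointing to a shift, the expectation is that compound 3 stays close to compound 1, with the step of a number 1 percentage points higher from compound 1 to compound 3 (within the scatter) expected to lie within the scatter. Compound 3 is therefore estimated at 14%, in a range from 4% to 28%.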

Compound 3, a percentage reported as activity, at one concentration (the size of the read-out at that concentration, not a potency): 12.2%
Beside the measured number, compound 3's estimate is 1.8 percentage points above it, within the range that was stated.
By their numbers in this assay, from the lowest: compounds 3, 1 and 2 (each within the scatter of the next).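

Within the data shown here, compound 3 is the first change made on an aromatic carbon of the six-membered aromatic ring of carbon only, rather than on a chain attached to that ring. In this assay the step is a number 0.8 percentage points lower from compound 1 to compound 3 (within the scatter), so a methoxy in place of hydrogen, ortho to a methoxy group and meta to a large group, makes no readable difference to the read-out. Nothing measured here speaks to what lies behind this result.

Among the compounds shown, this place on the ring holds only hydrogen or methoxy, so it remains open whether a group of another kind, such as an amine, a carboxylic acid or a fluorine atom, would give a number in this assay that stands clear of the scatter. As far as these compounds go, it also remains open whether a longer chain on the oxygen of the new group would behave as the methoxy does, and whether the same addition would give a similar result on the core of compound 2 as it does on the core of compound 1.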